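Working notes: removing the hydroxy in the bromo series

The source may hold more compounds than are shown below. What is called first, only, known or untested is meant among the compounds shown, and "the series" means these compounds.

Compound 1 `O=C(/C=C/c1cc(Br)ccc1O)c1ccc(Br)cc1` and compound 2 `Cc1ccc(C(=O)/C=C/c2cc(Br)ccc2O)cc1` share one core and differ in one place. Going by the values given here, in a functional assay on MCF7 cells (Homo sapiens) for antiproliferative activity, read by sulforhodamine B assay, with a stated time of 72 h, tested at 10 uM (a lower number here means a stronger effect, a higher number a weaker effect of the compound at the concentration tested), compound 1 gives 28.7% and compound 2 gives 27.3%; the only measured step, a number 1.4 percentage points lower from compound 1 to compound 2 (within the scatter), lies within the scatter, so the two numbers read as equal. Compound 2 stands with the lower of the two numbers, but only within the scatter of compound 1.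

Compound 3 `Cc1ccc(C(=O)/C=C/c2cccc(Br)c2)cc1` has not yet been measured. It differs from compound 2 by hydrogen in place of hydroxy on an aromatic carbon. Among the compounds with values here, no measured step bears on this change: the one step in hand swaps methyl for bromo, and no pair removes a hydroxy. The expectation therefore rests on the structural change alone, and a step toward a higher number in this assay is expected, with wide uncertainty. Compound 3 is estimated at 45% in this assay, between 20% and 75%. That estimate means an expected a number 17.7 percentage points higher from compound 2 to compound 3 (beyond the scatter).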

Compound 3, a percentage reported as activity, at one concentration (the size of the read-out at that concentration, not a potency): 60.4%
Compound 3: the middle estimate sits 15.4 percentage points below what was measured; measured number inside the range.
By their numbers in this assay, from the lowest: compounds 2 and 1 (each within the scatter of the next); then compound 3.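

Going by these compounds alone, the step of a number 33.1 percentage points higher from compound 2 to compound 3 (beyond the scatter) in this assay is the first to lie beyond the scatter, and it marks this position as one where the change registers, whereas the swap of methyl for bromo left the two numbers level. The hydroxy, ortho to a large group and para to a bromo group, thus goes with the stronger effect at the concentration tested, though this rests on a single pair of compounds. No measurement at hand accounts for the size of this step.

As far as these compounds go, it remains open whether the same loss would appear with bromo in place of the methyl of compound 3. The compounds shown also leave open whether a methoxy group or an amine at this position would keep the effect seen with the hydroxy.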